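The source may hold more compounds than are shown below. What is called first, only, known or untested is meant among the compounds shown, and "the series" means these compounds.

Compound 1 `Cc1cc(/C=C/C#N)cc(C)c1Oc1nc(Nc2ccc(N3CCCC(N)C3)cc2)nc2ccsc12`: 3820 nM
Compound 2 `Cc1cc(/C=C/C#N)cc(C)c1Oc1nc(Nc2ccc(N3CCN(S(N)(=O)=O)CC3)cc2)nc2ccsc12`: > 222000 nM (a limit)
Compound 3 `Cc1cc(/C=C/C#N)cc(C)c1Oc1nc(Nc2ccc(N3CCN(S(C)(=O)=O)CC3)cc2)nc2ccsc12`: 11500 nM

In an ADME assay on MT4 cells (Homo sapiens) for cytotoxicity, read by MTT assay, with a stated time of 5 days (a higher number here means that more compound is tolerated, a lower number that less compound is tolerated), compound 3 gives the higher of the two numbers recorded, with compound 1 nearest; the step of a 3.0-fold higher number from compound 1 to compound 3 (0.48 log units; beyond the scatter) separates them. For compound 2 the assay reports only a limit, (the limit of > 222000 nM in this assay, at which 1 of the 3 values shown sits), so no number stands there.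

Compound 4 `Cc1cc(/C=C/C#N)cc(C)c1Oc1nc(Nc2ccc(CN3CCN(S(N)(=O)=O)CC3)cc2)nc2ccsc12` differs from compound 3 in one place: (4-sulfamoylpiperazin-1-yl)methyl in place of 4-(methylsulfonyl)piperazin-1-yl on an aromatic carbon. Two parts of this change can be weighed. The exchange at the sulfonyl sulfur has a measured counterpart in the step of an at least 19-fold lower number from compound 2 to compound 3 (1.28 log units; beyond the scatter), and compound 4 carries the amino group of compound 2 at that position, so the reverse direction of that step bears on it and points toward a markedly higher number in this assay. The methylene that now links the piperazine to the aromatic ring has no measured counterpart among these three compounds, and nothing here tells how large its contribution is.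

Taken together, compound 4 is expected to sit well above compound 3, by a step of about a 13-fold higher number from compound 3 to compound 4 (1.12 log units; beyond the scatter). The estimate for compound 4 in this assay is therefore 150000 nM, within a range of 30000 nM to 400000 nM, with a real chance that only a limit is reported.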

Compound 4, half-maximal cytotoxic concentration: 145000 nM
The estimate for compound 4 lay 1.0-fold (0.01 log units) above the measured number; measured number inside the range.
By their numbers in this assay, from the lowest: compound 1; then compound 3; then compound 4. At a limit, above all of these: compound 2.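

In this assay, the (4-sulfamoylpiperazin-1-yl)methyl group in place of the 4-(methylsulfonyl)piperazin-1-yl group, a single change that brings both the amino group on the sulfonyl sulfur and a methylene link to the aromatic ring, gives a large step: a 13-fold higher number from compound 3 to compound 4 (1.10 log units; beyond the scatter). Against the 3-aminopiperidin-1-yl group the same substituent gives a 38-fold higher number from compound 1 to compound 4 (1.58 log units; beyond the scatter), and compound 4 supplies the first actual number for a compound with an amino group on the sulfonyl sulfur. Compound 2 is recorded only as a limit: the limit of > 222000 nM in this assay, at which 1 of the 4 values shown sits.

Against that limit only a floor can be given, an at least 1.5-fold lower number from compound 2 to compound 4 (0.18 log units; that floor lies within the scatter), and that is all that can be read of this step.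

The share of the methylene link therefore stays unsized, and the step from compound 3 cannot be divided between that link and the exchange at the sulfonyl sulfur. Also open, from the compounds shown here alone, is how the number would respond to a methyl group on the sulfonyl sulfur with the methylene link kept, or to a longer chain in place of the methylene, or to a 3-aminopiperidin-1-yl group attached through the same link.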